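Chloro for Hydrogen on Two Cores: Cytotoxicity Notes

A few compounds are considered here, and "the series" means these few. Any claim that something is new, unique, unknown or untested is made for them only; others in the source may bear on it.

The series is read in a functional assay on MCF7 cells (Homo sapiens) for cytotoxicity, read by MTT assay, with a stated time of 72 h; on this read-out lower numbers stand for stronger inhibition and higher numbers for weaker inhibition. Compound 2 `Cc1cc(C)nc(SCc2cc(=O)c3ccccc3o2)n1` sits at a limit of the assay, giving > 25000 nM. Compound 1 `Cc1cc(C)nc(SCc2cc(=O)c3cc(Cl)ccc3o2)n1` differs from compound 2 by chloro in place of hydrogen on an aromatic carbon. In this assay compound 1 is also reported only as a limit, at > 25000 nM. The change from compound 2 to compound 1 therefore yields a step that the two limits leave unreadable from compound 2 to compound 1, because both values rest at the limit of > 25000 nM in this assay, at which 3 of the 3 values shown sit.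

Compound 3 `Nc1nnc(SCc2cc(=O)c3ccccc3o2)s1` carries a different core; how its core differs from that of compound 2 is not broken down here. In this assay compound 3 is likewise reported as a limit, at > 25000 nM.

Compound 4 `Nc1nnc(SCc2cc(=O)c3cc(Cl)ccc3o2)s1` has not been measured. It differs from compound 3 by chloro in place of hydrogen on an aromatic carbon, the same change that takes compound 2 to compound 1.

Among the compounds with values here, from compound 3 to compound 4 the step is expected to be a step that the limit leaves unreadable from compound 3 to compound 4, since the identical change gave a step that the two limits leave unreadable from compound 2 to compound 1 and every value so far sits at the limit of > 25000 nM in this assay, at which 3 of the 3 values shown sit. Compound 4 is accordingly estimated at 35000 nM, with a range from 8000 nM to 150000 nM, most likely again reported only as a limit.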

Compound 4, half-maximal inhibitory concentration: > 25000 nM
Compound 4: a limit, no number; the forecaster's own chance of this, stated with the estimate: 80%; the middle value does not contradict the limit.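

In this assay no size can be read for chloro in place of hydrogen from compound 3 to compound 4, because both compounds are reported only as limits: the limit of > 25000 nM in this assay, at which 4 of the 4 values shown sit. The compounds shown leave open whether this change alters cytotoxicity on either core, and how far any of the four compounds lies past the limit.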